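A few compounds are considered here, and "the series" means these few. Any claim that something is new, unique, unknown or untested is made for them only; others in the source may bear on it.

- compound 1 `COc1ccc(/C=C2\CCC/C(=C\c3ccccc3Cl)C2=O)cc1OC`: 10400 nM
- compound 2 `COc1ccc(/C=C2\CCC/C(=C\c3ccc(Br)cc3)C2=O)cc1OC`: 6900 nM
- compound 3 `COc1ccc(/C=C2\CCC/C(=C\c3ccc(OC)c(OC)c3)C2=O)cc1`: 7800 nM

All three values come from a functional assay on MCF7 cells (Homo sapiens) for cytotoxicity, read by MTT assay, with a stated time of 72 h; on this read-out lower numbers stand for stronger inhibition and higher numbers for weaker inhibition. Compound 3, at 7800 nM, cannot be separated from the other two, as its steps to both lie within the scatter.

Compound 4 `COc1ccc(/C=C2\CCC/C(=C\c3cc(Cl)cc(Cl)c3)C2=O)cc1OC` has 3,5-dichlorophenyl in place of 4-methoxyphenyl on a double-bonded chain carbon bound to a double-bonded ring carbon. Two measured steps also exchange halogen for methoxy on a ring at this place, running in the reverse sense: a 1.3-fold lower number from compound 1 to compound 3 (0.12 log units; within the scatter) and a 1.1-fold higher number from compound 2 to compound 3 (0.05 log units; within the scatter). Both are small, and a 1.5-fold lower number from compound 1 to compound 2 (0.18 log units; within the scatter) shows that changing the halogen-bearing ring also moved little. Within the data shown here, no measured compound carries 3,5-dichlorophenyl, however, so this evidence is indirect.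

In this assay, no change beyond the scatter is therefore expected, and the expected result is a 1.1-fold lower number from compound 3 to compound 4 (0.05 log units; within the scatter). For compound 4 the estimated value is 7000 nM, with an expected range from 3000 nM to 14000 nM.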

Compound 4, half-maximal inhibitory concentration: 3800 nM
For compound 4 the middle estimate is 1.8-fold (0.27 log units) above the measured one, within the range that was stated.
By their numbers in this assay, from the lowest: compounds 4, 2, 3 and 1 (each within the scatter of the next, the first and the last beyond it).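

In this assay, among these compounds, the ring carried on this double-bonded chain carbon can shift the number beyond the scatter, which no earlier pair showed: 3,5-dichlorophenyl in place of 4-methoxyphenyl gives a modest step (a 2.1-fold lower number from compound 3 to compound 4 (0.31 log units; beyond the scatter)), and 3,5-dichlorophenyl in place of 2-chlorophenyl gives another (a 2.7-fold lower number from compound 1 to compound 4 (0.44 log units; beyond the scatter)). Halogen alone does not account for the pattern, as compound 1 also carries chlorine, while compound 4 cannot be separated from compound 2, which carries bromine (a 1.8-fold lower number from compound 2 to compound 4 (0.26 log units; within the scatter)). Nothing available explains these shifts.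

From the compounds shown here alone, whether a phenyl ring bearing an amine or a carboxylic acid at this place would move the number further remains open. So does whether both chlorine atoms of compound 4 are needed for its step.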